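Chloro Added to the Phenyl of Compound 3

A few compounds are considered here, and "the series" means these few. Any claim that something is new, unique, unknown or untested is made for them only; others in the source may bear on it.

Working notes on the series. In a functional assay on HL-60 cells (Homo sapiens) for cytotoxicity, read by MTT assay, with a stated time of 24 h (on this read-out lower numbers stand for stronger inhibition and higher numbers for weaker inhibition), compound 3 `CC(C)(C)c1ccc(-c2nn(CCCN3CCN(c4ccccc4)CC3)c(=S)[nH]2)cc1` reads > 300000 nM, which is a limit of the assay and not a number. Compound 1 `Cc1cccc(-c2nnc(SCCCN3CCN(c4ccccc4)CC3)[nH]2)c1` in this assay reads > 300000 nM, again a limit. Compound 2 `c1ccc(Cc2nnc(SCCCN3CCN(c4ccccn4)CC3)[nH]2)cc1` in this assay reads > 300000 nM, also a limit. Compound 3 therefore stands at the limit of > 300000 nM in this assay, at which 3 of the 3 values shown sit, and no measured value distinguishes it from compound 1 or compound 2; nothing among the three gives a step to compare.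

Compound 4 `CC(C)(C)c1ccc(-c2nn(CCCN3CCN(c4cccc(Cl)c4)CC3)c(=S)[nH]2)cc1` differs from compound 3 in one place: chloro in place of hydrogen on an aromatic carbon. For the measured compounds named here, no measured pair shows the effect of this change here, so no step beyond the usual scatter is expected in this assay, in either direction; the most likely outcome is another limit rather than a number. Compound 4 is accordingly expected to read about 400000 nM in this assay, within 150000 nM to 1000000 nM. The expected step that the limit leaves unreadable from compound 3 to compound 4 is thus essentially none.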

Compound 4, half-maximal inhibitory concentration: > 300000 nM
Compound 4 ended at the assay's limit; the forecaster's own chance of this, stated with the estimate: 80%; the middle value does not contradict the limit.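

In this assay no step can be read from compound 3 to compound 4, as both compounds give a limit and not a number: the limit of > 300000 nM in this assay, at which 4 of the 4 values shown sit. The compounds shown leave open whether any change in this series yields a measurable value in this read-out.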